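Chloro for Methyl on the Pyridine Ring of Compound 1

This account rests on a few compounds, and the source may have more. Where it says the series, first, only, none or still open, it means among the compounds named here.

Measured compounds:
Compound 1, `Cc1ccnc(NC(=O)c2ccccc2C)c1`: 129 uL/min
Compound 2, `Cc1ccnc(NC(=O)c2cccc(F)c2C)c1`: 237 uL/min
Compound 3, `Cc1ccccc1C(=O)Nc1ccc(F)cn1`: 43 uL/min

In an ADME assay (liver) for metabolic stability, with Liver microsome (Homo sapiens) as the target, read by LC-MS, using microsomes, with a stated time of 60 min, tested at 1 uM (a lower number here means slower removal, a higher number faster removal of the compound), compound 1 gives 129 uL/min, the second highest of the three numbers. Compound 2 lies nearest to it, and the step of a 1.8-fold higher number from compound 1 to compound 2 (0.26 log units; within the scatter) is within the scatter, so the two compounds cannot be ranked. Compound 3 gives 43 uL/min, the lower of the two values, and the gap between compound 3 and compound 1 is beyond the scatter.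

Compound 4, `Cc1ccccc1C(=O)Nc1cc(Cl)ccn1`, has not been measured in this assay. It differs from compound 1 by chloro in place of methyl on an aromatic carbon. Going by the values given here, no measured step covers this change: the one step available, from compound 1 to compound 2, concerns a different ring and was within the scatter. Compound 3 shows that a change on the ring bearing the amide nitrogen can move the number beyond the scatter, but that change is not the same one. The step of a 1.5-fold lower number from compound 1 to compound 4 (0.18 log units; within the scatter) is therefore expected to be modest and downward. Compound 4 is estimated at 85 uL/min, between 35 uL/min and 200 uL/min.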

Compound 4, intrinsic clearance in a liver preparation (reported as CLH), per the amount of preparation that the assay uses in the Liver microsome assay: 128 uL/min
The estimate for compound 4 lay 1.5-fold (0.18 log units) below the measured number, and the stated range covers the measured number.
By their numbers in the Liver microsome assay, from the lowest: compound 3; then compounds 4, 1 and 2 (each within the scatter of the next).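

Going by these compounds alone, in the Liver microsome assay, chloro in place of methyl opposite the ring nitrogen gives the first measured step at this position, and it is a 1.0-fold lower number from compound 1 to compound 4 (0.00 log units; within the scatter), so the two compounds cannot be ranked. In a physicochemical assay for lipophilicity, read by HPLC, at pH 7.4 (on this read-out lower numbers stand for lower lipophilicity and higher numbers for higher lipophilicity), compound 1 gives 2.8 and compound 4 gives 3.4, a gap that lies beyond the scatter. This change therefore separates the two compounds on lipophilicity but not on their removal by the liver preparation, a pairing the earlier compounds did not show: the measured distribution coefficient of compound 1, 2.8, and of compound 4, 3.4, a number 0.60 log units higher (beyond the scatter)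

Only methyl and chloro are shown at this position, so it remains open how an amine or a methoxy group there would compare with them. Going by these compounds, it is also open whether chloro would give the same result on the fluoro-bearing core of compound 2.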